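Cytotoxicity series: aryl variation on the enol chain

The source may report more compounds than this note shows. Statements on the series, on what has been measured and on what is new or still open speak of the compounds shown alone.

Measured so far:
Compound 1 `COC1=C(C)C(=O)/C(=C(O)/C=C/c2ccc(Br)cc2)C(=O)C1(C)C`: 9 ug/mL
Compound 2 `COC1=C(C)C(=O)/C(=C(O)/C=C/c2c(C)cccc2C)C(=O)C1(C)C`: 10.1 ug/mL
Compound 3 `C=Cc1ccccc1/C=C/C(O)=C1/C(=O)C(C)=C(OC)C(C)(C)C1=O`: 2.6 ug/mL

In a functional assay on A-431 cells (Homo sapiens) for cytotoxicity (on this read-out lower numbers stand for an effect already at smaller amounts and higher numbers for an effect only at larger amounts of compound), compound 1 gives 9 ug/mL and stands second highest of the three numbers; it sits close to compound 2 (a 1.1-fold higher number from compound 1 to compound 2 (0.05 log units; within the scatter)) and furthest from compound 3 (a 3.5-fold lower number from compound 1 to compound 3 (0.54 log units; beyond the scatter)). Compound 4 `COC1=C(C)C(=O)/C(=C(O)/C=C/c2ccco2)C(=O)C1(C)C` is not yet measured; it differs from compound 1 by furan-2-yl in place of 4-bromophenyl on a double-bonded chain carbon bound to a double-bonded chain carbon.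

For the measured compounds named here, two steps bear on this change, both on the same double-bonded chain carbon: 2,6-dimethylphenyl in place of 4-bromophenyl (a 1.1-fold higher number from compound 1 to compound 2 (0.05 log units; within the scatter), within the scatter) and 2-vinylphenyl in place of 4-bromophenyl (a 3.5-fold lower number from compound 1 to compound 3 (0.54 log units; beyond the scatter), modest). Going by the values given here, neither involves a five-membered aromatic ring with a hetero atom, so no direct precedent exists for furan-2-yl. Compound 4 is therefore expected to land near compound 1 in this assay, with no change at the digits printed from compound 1 to compound 4 (within the scatter) expected to lie within the scatter and the range widened for the lack of a close analog. The estimate for compound 4 is 9 ug/mL, between 3 ug/mL and 27 ug/mL.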

Compound 4, concentration for half-maximal effect: 14.7 ug/mL
Estimate against measurement, compound 4: 1.6-fold (0.21 log units) below, and the stated range covers the measured number.
By their numbers in this assay, from the lowest: compound 3; then compounds 1, 2 and 4 (each within the scatter of the next).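

In this assay, furan-2-yl, a five-membered aromatic ring with 1 hetero atom, stays level with both other aryl groups at this double-bonded chain carbon: a 1.6-fold higher number from compound 1 to compound 4 (0.21 log units; within the scatter) and a 1.5-fold higher number from compound 2 to compound 4 (0.16 log units; within the scatter). Against 2-vinylphenyl the gap is larger, a 5.7-fold higher number from compound 3 to compound 4 (0.75 log units; beyond the scatter), which leaves compound 3 alone at the low end of the series. No measured evidence accounts for these numbers.

Open, from the compounds shown here alone, is whether thiophen-2-yl would match furan-2-yl at this carbon. Also open, going by these compounds, is what an amine or a carboxylic acid on the aryl ring would give.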